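The source may report more compounds than this note shows. Statements on the series, on what has been measured and on what is new or still open speak of the compounds shown alone.

Compound 2 `CC(C)c1cccc(C(C)C)c1NC(=O)NCC1(c2ccc(NCCO)cc2)CCCC1` gives 25 nM in an assay on microsomes for inhibition of acyl-CoA:cholesterol acyltransferase (Oryctolagus cuniculus) (on this read-out higher numbers stand for weaker inhibition and lower numbers for stronger inhibition), the lowest of the two numbers measured, though compound 1 `CC(C)c1cccc(C(C)C)c1NC(=O)NCC1(c2ccc(OCc3ccccc3)cc2)CCCC1` with 34 nM lies within the scatter of it. Compound 3 `CC(C)c1cccc(C(C)C)c1NC(=O)NCC1(c2ccc(C(=O)O)cc2)CCCC1` differs from compound 2 by carboxy in place of (2-hydroxyethyl)amino on an aromatic carbon. Among the compounds with values here, the only comparison at this position is a 1.4-fold lower number from compound 1 to compound 2 (0.13 log units; within the scatter), a change that stayed within the scatter. That single step gives no firm direction for a carboxy group, so a step of about a 3.2-fold higher number from compound 2 to compound 3 (0.51 log units; beyond the scatter) is expected, with weaker inhibition somewhat more likely than stronger. Compound 3 is estimated at 80 nM, within a range from 20 nM to 400 nM.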

Compound 3, half-maximal inhibitory concentration: 3100 nM
Compound 3: middle estimate off by 39-fold (1.59 log units), on the low side; measured number outside the range, above it.
By their numbers in this assay, from the lowest: compounds 2 and 1 (each within the scatter of the next); then compound 3.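

In this assay this position, para to a large group, does not accept every group: benzyloxy and (2-hydroxyethyl)amino lie within the scatter of each other, yet a 120-fold higher number from compound 2 to compound 3 (2.09 log units; beyond the scatter) and a 91-fold higher number from compound 1 to compound 3 (1.96 log units; beyond the scatter) follow when carboxy takes their place. Two very different groups being accepted therefore did not mean that any group would be. No measurement available here accounts for this change. Still open, on these data alone, is whether the loss belongs to the carboxy group itself, as a methyl ester or a primary amide at this place would show. A carboxylic acid on a longer chain could show whether the distance from the ring matters.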